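The compounds below may be only part of what the source reports. "The series", "measured", "known", "first", "only" and "open" are said of these compounds alone.

Measured so far:
Compound 1 `COc1ccc(/C=C\c2cc(OC)c(OC)c(OC)c2)cc1OCc1ccc(C=O)cc1` — 46000 nM
Compound 2 `COc1ccc(/C=C\c2cc(OC)c(OC)c(OC)c2)cc1OCc1ccc(CN2C[C@H](O)C[C@@H]2C(=O)O)cc1` — > 50000 nM
Compound 3 `COc1ccc(/C=C\c2cc(OC)c(OC)c(OC)c2)cc1OCc1ccc(CN2CC[C@H](C(=O)O)C2)cc1` — > 50000 nM

Compound 1 is the only one of the three that gives a number in an ADME assay on HEK293 cells (Homo sapiens) for cytotoxicity, read by CCK-8 assay, with a stated time of 48 h (on this read-out lower numbers stand for stronger inhibition and higher numbers for weaker inhibition), where compound 1 shows 46000 nM. For compound 2 this assay reports only a limit, > 50000 nM, and not a number. For compound 3 the same assay likewise reports only a limit, > 50000 nM. The steps from compound 1 are therefore floors: an at least 1.0-fold higher number from compound 1 to compound 2 (0.03 log units; that floor lies within the scatter) and an at least 1.0-fold higher number from compound 1 to compound 3 (0.03 log units; that floor lies within the scatter). Between the two limit values the step is a step that the two limits leave unreadable from compound 2 to compound 3, and the reason such steps stay unreadable is the limit of > 50000 nM in this assay, at which 2 of the 3 values shown sit.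

Compound 4 `COc1ccc(/C=C\c2cc(OC)c(OC)c(OC)c2)cc1OCc1ccc(CN[C@H](C(=O)O)[C@@H](C)O)cc1` is not yet measured in this assay. It differs from compound 2 by (1-carboxy-2-hydroxypropyl)amino in place of 2-carboxy-4-hydroxypyrrolidin-1-yl on a saturated chain carbon bound to an aromatic carbon. Among the compounds with values here, the one measured step that bears on a change of this kind is the exchange of the pyrrolidine substituent from compound 2 to compound 3, and that step is unreadable; the two steps from compound 1 give only floors that lie within the scatter. No step beyond the scatter is therefore expected in this assay, and the number is most likely to land again at the limit. Compound 4 is expected near 60000 nM, between 30000 nM and 150000 nM. That estimate means an expected step that the limit leaves unreadable from compound 2 to compound 4.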

Compound 4, half-maximal inhibitory concentration: > 50000 nM
Compound 4 was reported as a limit (the forecaster's own chance of this, stated with the estimate: 75%); the middle value lies beyond the limit too.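

Compound 4 shows that at this place, on a saturated chain carbon bound to an aromatic carbon, the ring of 2-carboxy-4-hydroxypyrrolidin-1-yl can give way to the open (1-carboxy-2-hydroxypropyl)amino group while the entry in this assay remains a limit and not a number. Against the formyl compound the change yields only a floor: an at least 1.0-fold higher number from compound 1 to compound 4 (0.03 log units; that floor lies within the scatter). The steps among compound 2, compound 3 and compound 4 cannot be read, so no order can be given among them, and the open-chain group now joins the two ring groups at the same ceiling: the limit of > 50000 nM in this assay, at which 3 of the 4 values shown sit.

Going by these compounds, it remains open whether a group at this place without the carboxylic acid, such as a simple amine or a hydroxymethyl, would give a readable number in this assay. On these data alone, it also remains open whether an amino acid group on a longer chain would do so, and how far any of the three limit compounds actually lies from compound 1.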